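Lengthening the Imidazole Nitrogen Chain in a GnRH Receptor Series

The compounds below may be only part of what the source reports. "The series", "measured", "known", "first", "only" and "open" are said of these compounds alone.

Compound 2 `Cc1nc(CN2CCN(c3cccc4[nH]c(-c5ccc(C(C)(C)C)cc5)nc34)CC2)cn1C` is the stronger of the two measured compounds in an assay on isolated protein for displacement of a labelled ligand from Gonadotropin-releasing hormone receptor (Homo sapiens); a lower number here means a stronger inhibitor, a higher number a weaker inhibitor: compound 2 gives 10 nM, while compound 1 `Cc1ccc(CN2CCN(c3cccc4[nH]c(-c5ccc(C(C)(C)C)cc5)nc34)CC2)o1` gives 705 nM. Within the data shown here, the one measured step, a 71-fold lower number from compound 1 to compound 2 (1.85 log units; beyond the scatter), put 1,2-dimethyl-1H-imidazol-4-yl in place of 5-methylfuran-2-yl. Compound 3 `CCCn1cc(CN2CCN(c3cccc4[nH]c(-c5ccc(C(C)(C)C)cc5)nc34)CC2)nc1C` keeps that imidazole and differs from compound 2 only by ethyl in place of hydrogen on a saturated chain carbon bound to an aromatic nitrogen, which reads methyl to propyl on the aromatic nitrogen. Among the measured compounds shown here, no measured pair touches this part of the molecule; the step from compound 1 to compound 2 exchanges the whole ring group and says nothing about a longer chain on its nitrogen. Without a guide, only a modest shift in either direction, or none beyond the scatter, is expected, a 1.5-fold higher number from compound 2 to compound 3 (0.18 log units; within the scatter). Compound 3 is therefore estimated at 15 nM, with a range from 4 nM to 60 nM.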

Compound 3, half-maximal inhibitory concentration in the Gonadotropin-releasing hormone receptor assay: 18 nM
Estimate against measurement, compound 3: 1.2-fold (0.08 log units) below; the range from low to high includes it.
By their numbers in the Gonadotropin-releasing hormone receptor assay, from the lowest: compounds 2 and 3 (each within the scatter of the next); then compound 1.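

In the Gonadotropin-releasing hormone receptor assay, compound 2 gives 10 nM and compound 3 gives 18 nM; the change from methyl to propyl on the imidazole nitrogen gives a 1.8-fold higher number from compound 2 to compound 3 (0.26 log units; within the scatter), so this position accepts the longer chain without a shift that can be told from the scatter. The gain over the furan also holds with propyl in place of methyl, with a 39-fold lower number from compound 1 to compound 3 (1.59 log units; beyond the scatter), and so does not depend on the methyl group of compound 2. In a physicochemical assay for solubility, at pH 7.4 (on this read-out lower numbers stand for lower solubility and higher numbers for higher solubility), compound 2 gives 51 ug/mL and compound 3 gives 55 ug/mL; the change gives a 1.1-fold higher number from compound 2 to compound 3 (0.03 log units; within the scatter), also within the scatter, and no supporting measurement accounts for either result.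

Going by these compounds, it remains open how far this acceptance extends, whether to a longer chain such as hexyl or a branched one such as isopropyl. A chain ending in an amine or a carboxylic acid on this nitrogen also remains an open case.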